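Methoxy to hydroxy on the shared core: an expectation

The compounds below may be only part of what the source reports. "The series", "measured", "known", "first", "only" and "open" are said of these compounds alone.

Measured so far:
compound 1 `Cc1cc(O)cc(-c2nn(CC#N)cc2-c2ccnc(-c3ccc(Oc4ccccc4)cc3)c2)c1`: 2320 nM
compound 2 `COc1cc(C)cc(-c2nn(CC#N)cc2-c2ccnc(-c3ccc(N(C)C)cc3)c2)c1`: 235 nM

In a functional assay on MDA-MB-435 cells (Homo sapiens) for inhibition, read by sulforhodamine B assay, with a stated time of 48 h (a lower number here means a stronger inhibitor of growth, a higher number a weaker inhibitor of growth), compound 2 gives the lower of the two numbers, and compound 1 sits at the higher one, a gap beyond the scatter. Compound 3 `Cc1cc(O)cc(-c2nn(CC#N)cc2-c2ccnc(-c3ccc(N(C)C)cc3)c2)c1` has not been measured. It differs from compound 2 by hydrogen in place of methyl on an oxygen on an aromatic ring: methoxy to hydroxy. Among the measured compounds shown here, no measured pair isolates this single change, so the direction of the step is uncertain; a small step, or none beyond the scatter, is expected, a 1.4-fold higher number from compound 2 to compound 3 (0.13 log units; within the scatter). Compound 3 is therefore estimated at 320 nM, within 110 nM to 1000 nM.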

Compound 3, concentration for 50% growth inhibition: 1010 nM
Compound 3: the middle estimate sits 3.2-fold (0.50 log units) below what was measured; measured number above the stated range.
By their numbers in this assay, from the lowest: compound 2; then compound 3; then compound 1.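

In this assay the methyl on this oxygen counts: methoxy to hydroxy gives a 4.3-fold higher number from compound 2 to compound 3 (0.63 log units; beyond the scatter) with dimethylamino held constant. Compound 3 also isolates a second site, where dimethylamino in place of phenoxy on an aromatic carbon gives a 2.3-fold lower number from compound 1 to compound 3 (0.36 log units; beyond the scatter) with the hydroxy held constant. Nothing shown gives a cause for either step.

The compounds shown leave open where an ethoxy group or an amine at the methoxy position would fall relative to compound 2 and compound 3. They also leave open whether the methoxy to hydroxy step keeps its size with phenoxy in place of dimethylamino.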